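A Methyl Removed Twice on Related Side Chains

The source may hold more compounds than are shown below. What is called first, only, known or untested is meant among the compounds shown, and "the series" means these compounds.

The series rests on compound 1, `C[C@H](NC(=O)CN(c1nc(Cl)nc2[nH]cnc12)C1CC1)C(=O)OCc1ccccc1`, which in a functional assay on the whole organism (Tail, strain ICR) with Mus musculus as the target, in the tail flick test, with a stated time of 150 min, at a dose of 25 umol/kg by the oral route (on this read-out higher numbers stand for a stronger effect at the one dose given and lower numbers for a weaker effect), gives 23%. Compound 2, `O=C(CN(c1nc(Cl)nc2[nH]cnc12)C1CC1)NCC(=O)OCc1ccccc1`, differs from it by hydrogen in place of methyl on a saturated chain carbon bound to an amide-type nitrogen and a carbonyl carbon, and in this assay compound 2 gives 18%; the step of a number 5 percentage points lower from compound 1 to compound 2 (within the scatter) stays within the scatter of repeated measurements. Compound 3, `C[C@@H](O)[C@H](NC(=O)CN(c1ncnc2c1ncn2C1CCCCO1)C1CC1)C(=O)OCc1ccccc1`, carries a different core; the difference between the two cores is not broken down here. In this assay compound 3 gives 6.53%, the lowest of the three numbers and beyond the scatter from both compound 2 and compound 1.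

Compound 4, `O=C(CN(c1ncnc2c1ncn2C1CCCCO1)C1CC1)N[C@@H](CO)C(=O)OCc1ccccc1`, has not been measured. It differs from compound 3 by hydrogen in place of methyl on a saturated chain carbon bound to an oxygen on a saturated carbon and a saturated chain carbon. This is the same kind of change as that from compound 1 to compound 2, though not the same: there the place was a saturated chain carbon bound to an amide-type nitrogen and a carbonyl carbon, whereas here it is a saturated chain carbon bound to an oxygen on a saturated carbon and a saturated chain carbon.

The step of a number 0.5 percentage points lower from compound 3 to compound 4 (within the scatter) is expected to be small, because the earlier removal of a methyl produced only a number 5 percentage points lower from compound 1 to compound 2 (within the scatter), a change within the scatter. For compound 4 the estimated reading in this assay is therefore 6%, most likely between 0% and 16%, close to the number seen for compound 3.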

Compound 4, a percentage reported as activity, at one dose (the size of the read-out at that dose, not a potency): 18.3%
Estimate against measurement, compound 4: 12.3 percentage points below; measured number above the stated range.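

In this assay, replacing the methyl with hydrogen, which turns 1-hydroxyethyl into hydroxymethyl, gives a number 11.8 percentage points higher from compound 3 to compound 4 (beyond the scatter). Set beside the earlier removal of a methyl, this shows that the size of the step does not carry over unchanged from one core to the other among these compounds: the same change on two cores in this assay, a number 5 percentage points lower (within the scatter) from compound 1 to compound 2 and a number 11.8 percentage points higher (beyond the scatter) from compound 3 to compound 4, 16.8 percentage points apart, beyond the scatter of two such steps It does not show what sets the two steps apart, for the cores differ and so do the places of the change, one being on a saturated chain carbon bound to an amide-type nitrogen and a carbonyl carbon and the other on a saturated chain carbon bound to an oxygen on a saturated carbon and a saturated chain carbon, and with only one pair on each core the two differences cannot be separated.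

The compounds shown leave open how the 1-hydroxyethyl and hydroxymethyl side chains would read on the core of compound 1, which would set the same change at the same place on both cores. They also leave open how a longer chain, an amine or a carboxylic acid in place of the hydroxymethyl would read on the core of compound 4.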